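A few compounds are considered here, and "the series" means these few. Any claim that something is new, unique, unknown or untested is made for them only; others in the source may bear on it.

Measured compounds:
- compound 1 `C=C(Br)C(=O)Nc1cccc(-c2cn3nc(-c4ccc(C)cc4)sc3n2)c1`: 1700 nM
- compound 2 `Nc1cccc(-c2cn3nc(-c4ccc(Cl)cc4)sc3n2)c1`: > 250000 nM (a limit of the assay, not a number)
- compound 3 `CCOc1ccc(-c2nn3cc(-c4cccc(N)c4)nc3s2)cc1`: > 250000 nM (a limit of the assay, not a number)

In a functional assay on CCRF-CEM cells (Homo sapiens) for inhibition, read by cell counting, with a stated time of 3 days (a lower number here means a stronger inhibitor, a higher number a weaker inhibitor), compound 3 gives > 250000 nM, which is a limit of the assay rather than a measured number. Compound 2 also stops at a limit, > 250000 nM. Compound 1, which carries a different group on the ring bearing the amine in the other two, gives 1700 nM. the limit of > 250000 nM in this assay, at which 2 of the 3 values shown sit, marks where two of the three values rest. The unmeasured compound 4 `Cc1ccc(-c2nn3cc(-c4cccc(N)c4)nc3s2)cc1` differs from compound 3 in one place: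

methyl in place of ethoxy on an aromatic carbon

Among the measured compounds shown here, the one measured step, a step that the two limits leave unreadable from compound 2 to compound 3, runs between two limits, so its size cannot be read and it offers no guide to direction. For the measured compounds named here, no step connects compound 1 to compound 3 or compound 4; its value shows only that a compound bearing the same methyl can register a number in this assay.

Going by the values given here, because the only measured step that the two limits leave unreadable from compound 2 to compound 3 is unreadable, compound 4 is expected to remain near the limit, at about 250000 nM, within 60000 nM to 400000 nM. The step expected is a number no higher from compound 3 to compound 4 (the limit leaves the size open), none beyond scatter.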

Compound 4, half-maximal inhibitory concentration: 5900 nM
Beside the measured number, compound 4's estimate is 42-fold (1.63 log units) above it; measured number outside the range, below it.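

In this assay, the group on the aromatic carbon para to a large group decides whether these amine compounds give a readable number at all: methyl in place of ethoxy gives an at least 42-fold lower number from compound 3 to compound 4 (1.62 log units; beyond the scatter), and methyl in place of chloro gives an at least 42-fold lower number from compound 2 to compound 4 (1.62 log units; beyond the scatter). Both sizes are minimums, because each step starts from a limit of the assay: the limit of > 250000 nM in this assay, at which 2 of the 4 values shown sit. The (1-bromoethenyl)carbonyl group on the nitrogen is also not required for a measurable number, since hydrogen in its place gives only a 3.5-fold higher number from compound 1 to compound 4 (0.54 log units; beyond the scatter).

The step between the two limits cannot be read, which leaves chloro and ethoxy unranked against each other. As far as these compounds go, whether an ethyl group or a methoxy group at this position would also give a measurable number remains open.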